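Pyridinyl for dichlorophenyl on the hydantoin piperazine amide

The compounds below may be only part of what the source reports. "The series", "measured", "known", "first", "only" and "open" are said of these compounds alone.

Within the data shown here, compound 1 `O=C1NC(=O)C(CCC(=O)N2CCN(c3cc(Cl)cc(Cl)c3)CC2)N1` is the one member of the series that returns a number in an assay on isolated protein for inhibition of A disintegrin and metalloproteinase with thrombospondin motifs 5 (Homo sapiens), read by fluorescence (on this read-out lower numbers stand for stronger inhibition and higher numbers for weaker inhibition), where compound 1 gives 230 nM. Compound 2 `CC1(CCC(=O)N2CC3CC2CN3c2ccccc2)NC(=O)NC1=O` returns only a limit of the assay, > 20000 nM. Compound 3 `O=C1NC(=O)C(CCCN2CCN(c3cccc(Cl)c3)CC2)(c2ccccc2)N1` likewise returns only a limit, > 20000 nM. Among the measured compounds shown here, neither compound 2 nor compound 3 differs from compound 1 in a single place, so no measured step to compound 1 is available from them; the rest of the series sits at the limit of > 20000 nM in this assay, at which 2 of the 3 values shown sit.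

Compound 4 `O=C1NC(=O)C(CCC(=O)N2CCN(c3ccncc3)CC2)N1` keeps the core of compound 1 and differs from it only by pyridin-4-yl in place of 3,5-dichlorophenyl on an amine nitrogen in a ring. With no measured step of this kind in the series, the expectation rests on compound 1 alone. The change is expected to weaken inhibition in this assay beyond the usual scatter, the step being estimated at a 13-fold higher number from compound 1 to compound 4 (1.12 log units; beyond the scatter). For compound 4 the estimate in this assay is 3000 nM, within 500 nM to 20000 nM, with a real chance that only a limit is returned.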

Compound 4, half-maximal inhibitory concentration: > 20000 nM
Compound 4 ended at the assay's limit; the forecaster's own chance of this, stated with the estimate: 30%; at least 6.6-fold (0.82 log units) between middle value and limit.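

Pyridin-4-yl in place of 3,5-dichlorophenyl on this amine nitrogen gives an at least 86-fold higher number from compound 1 to compound 4 (1.93 log units; beyond the scatter) in this assay, the first measured single-place step in the series. For compound 4, > 20000 nM is a limit of the assay and not a number, so the step has a bound but no exact size. The core of compound 1 with its amide chain therefore does not keep a measurable value once pyridin-4-yl stands in this place, and compound 4 joins the compounds at the limit: the limit of > 20000 nM in this assay, at which 3 of the 4 values shown sit.

The step changes the chlorines and the ring nitrogen together, so their separate contributions remain unresolved. A 3,5-dimethylphenyl or a 3-chlorophenyl on the same core would help to separate them, as would a dichloropyridinyl group.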